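Bromo in place of methoxy on an aryl ether tail

The source may report more compounds than this note shows. Statements on the series, on what has been measured and on what is new or still open speak of the compounds shown alone.

Three compounds sharing one core were tested in an assay on isolated protein for inhibition of Dihydrofolate reductase (Homo sapiens), read by spectrophotometry, using NADPH, with stated times of 5 s and 6 min, tested at 5 uM; a lower number here means a weaker effect, a higher number a stronger effect of the compound at the concentration tested:
compound 1 `NC1=NC2(CCOCC2)N(OCCCOc2cccc(Cl)c2)C(N)=N1` gives 83.2%
compound 2 `NC1=NC2(CCOCC2)N(OCCCOc2ccc(F)cc2)C(N)=N1` gives > 90%
compound 3 `COc1ccc(OCCCON2C(N)=NC(N)=NC23CCOCC3)cc1` gives > 90%

The value of compound 3 is a limit of the assay and not a number. Compound 2 also sits at a limit, so that (the limit of > 90% in this assay, at which 2 of the 3 values shown sit). Only compound 1 returns a plain number, and from it the two readable steps are a number at least 6.8 percentage points higher from compound 1 to compound 2 (that floor lies within the scatter) and a number at least 6.8 percentage points higher from compound 1 to compound 3 (that floor lies within the scatter). The direct comparison of the two para-substituted phenyl ethers is a step that the two limits leave unreadable from compound 2 to compound 3, so it cannot guide anything.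

Compound 4 `NC1=NC2(CCOCC2)N(OCCCOc2ccc(Br)cc2)C(N)=N1` differs from compound 3 by bromo in place of methoxy on an aromatic carbon. Going by the values given here, the only measured step at that place is the unreadable one, so what remains is that both para-substituted phenyl ethers, compound 2 and compound 3, reach the limit, while the 3-chlorophenyl ether of compound 1 lies a little lower, within scatter. Compound 4 is therefore expected to stay near the limit, with an expected step of a number at least 1 percentage points lower from compound 3 to compound 4 (that floor lies within the scatter) that is within the scatter. The estimate for compound 4 is 89%, in a range from 78% to 96%.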

Compound 4, a percentage reported as inhibition, at one concentration (the size of the read-out at that concentration, not a potency): > 90%
Compound 4: a limit, no number (the forecaster's own chance of this, stated with the estimate: 50%); middle value at least 1 percentage points from the limit.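

In this assay compound 4 gives > 90%, which is a limit of the assay and not a number. Bromo thus joins fluoro and methoxy as a third group on this aromatic carbon that reaches the limit, while the comparison with the 3-chlorophenyl ether is a number at least 6.8 percentage points higher from compound 1 to compound 4 (that floor lies within the scatter), so only a small floor can be stated for that change. The steps to compound 4 from compound 2 and compound 3 cannot be read, and the assay gives no order among these three groups: the limit of > 90% in this assay, at which 3 of the 4 values shown sit.

Going by these compounds, whether compound 2, compound 3 and compound 4 differ from one another remains open. Also open, on these data alone, is what an amine or a carboxylic acid at this place on the ring would give, and whether a longer chain in the tail would keep the effect.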